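The compounds below may be only part of what the source reports. "The series", "measured", "known", "first", "only" and "open" are said of these compounds alone.

Of the compounds shown here, two of a shared core have been measured in a functional assay on NCI-H1299 cells (Homo sapiens) for antiproliferative activity, read by MTT assay, with a stated time of 72 h (a lower number here means a stronger inhibitor, a higher number a weaker inhibitor), so far. Compound 1 `CCOC1=C(C(=O)c2ccccc2)C(c2ccc(Br)cc2)N(CCCn2ccnc2)C1=O` gives 28900 nM in this assay, and compound 2 `O=C(C1=C(Nc2ccccc2)C(=O)N(CCCn2ccnc2)C1c1ccc(Br)cc1)c1ccccc1` gives 21200 nM. For the measured compounds named here, the one step between them, anilino in place of ethoxy on a double-bonded ring carbon, is a 1.4-fold lower number from compound 1 to compound 2 (0.13 log units; within the scatter). Compound 2 thus stands at the lower of the two numbers, but the gap to compound 1 is within the scatter, so no order between them can be claimed.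

Compound 3 `O=C(C1=C(Nc2ccc(Cl)cc2)C(=O)N(CCCn2ccnc2)C1c1ccc(Br)cc1)c1ccccc1` differs from compound 2 by chloro in place of hydrogen on an aromatic carbon, that is, the anilino becomes a (4-chlorophenyl)amino. Going by the values given here, no measured step touches the anilino ring, so nothing among the numbers speaks for or against a change, and a step within the scatter is expected as a 1.3-fold lower number from compound 2 to compound 3 (0.12 log units; within the scatter). Compound 3 is therefore estimated at 16000 nM in this assay, with a range from 6000 nM to 40000 nM.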

Compound 3, half-maximal inhibitory concentration: 25000 nM
Compound 3: middle estimate off by 1.6-fold (0.19 log units), on the low side; the measured number falls inside the stated range.
By their numbers in this assay, from the lowest: compounds 2, 3 and 1 (each within the scatter of the next).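

Chloro in place of hydrogen, the first change on the anilino ring itself and placed para to a large group, gives a 1.2-fold higher number from compound 2 to compound 3 (0.07 log units; within the scatter) in this assay and so leaves hydrogen and chloro at this position indistinguishable. The (4-chlorophenyl)amino in place of ethoxy gives a 1.2-fold lower number from compound 1 to compound 3 (0.06 log units; within the scatter) and likewise does not separate these two compounds, so all three compounds now lie within the scatter of one another. No evidence is available that bears on this result.

Going by these compounds, it remains open whether a methoxy, an amine or a carboxylic acid in place of the chloro would move the number beyond the scatter. On these data alone, it is also open whether a benzylamino in place of the anilino would do so.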